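Methyl in place of methoxy on the amide aryl ring

A few compounds are considered here, and "the series" means these few. Any claim that something is new, unique, unknown or untested is made for them only; others in the source may bear on it.

Measured compounds:
compound 1 `O=C(Nc1cccc(-c2oc3cc(-c4ccc(F)cc4)ccc3c(=O)c2O)c1)c1ccc(F)cc1` — 14600 nM
compound 2 `COc1cccc(C(=O)Nc2cccc(-c3oc4cc(-c5ccc(F)cc5)ccc4c(=O)c3O)c2)c1` — 12500 nM

Both numbers come from a functional assay on GTL 16 cells for antiproliferative activity against GTL 16 cell line (Homo sapiens), read by CCK-8 assay, with a stated time of 72 h; a higher number here means a weaker inhibitor, a lower number a stronger inhibitor. Among the compounds with values here, compound 2 and compound 1 cannot be told apart there: the single step so far, a 1.2-fold lower number from compound 1 to compound 2 (0.07 log units; within the scatter), lies within the scatter, so compound 2 stands level with compound 1.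

Compound 3 `Cc1cccc(C(=O)Nc2cccc(-c3oc4cc(-c5ccc(F)cc5)ccc4c(=O)c3O)c2)c1` differs from compound 2 by methyl in place of methoxy on an aromatic carbon. Within the data shown here, the only step bearing on it, a 1.2-fold lower number from compound 1 to compound 2 (0.07 log units; within the scatter), also changed the aryl group on the carbonyl and stayed within the scatter; no methoxy-to-methyl step has been measured. The expected step is therefore no change at the digits printed from compound 2 to compound 3 (within the scatter), nothing beyond the scatter. Compound 3 is expected to give 12500 nM in this assay, with a range of 6000 nM to 26000 nM.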

Compound 3, half-maximal inhibitory concentration: 10900 nM
The estimate for compound 3 lay 1.1-fold (0.06 log units) above the measured number; the measured number falls inside the stated range.
By their numbers in this assay, from the lowest: compounds 3, 2 and 1 (each within the scatter of the next).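

At this aryl position, methyl in place of methoxy gives a 1.1-fold lower number from compound 2 to compound 3 (0.06 log units; within the scatter) in this assay, so removing the oxygen, with its one hydrogen-bond acceptor, does not separate the two compounds. The wider aryl change gives a 1.3-fold lower number from compound 1 to compound 3 (0.13 log units; within the scatter), leaving 4-fluorophenyl, 3-methoxyphenyl and 3-methylphenyl on the carbonyl indistinguishable in this set. No supporting data bear on this flat result.

Still open, from the compounds shown here alone, is whether an amine, a carboxylic acid or a longer alkyl chain in place of methyl would move the number beyond the scatter.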